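The source may report more compounds than this note shows. Statements on the series, on what has been measured and on what is new or still open speak of the compounds shown alone.

In a functional assay on MCF7 cells (Homo sapiens) for inhibition, read by CCK-8 assay, with a stated time of 48 h (a lower number here means a stronger inhibitor of growth, a higher number a weaker inhibitor of growth), the measured compounds give:
compound 1 `CN1CCN(c2ccc(Nc3ncc(Cl)c(NCc4ccc(C(F)(F)F)cc4)n3)nc2)CC1` at 28400 nM
compound 2 `CCc1ccc(Nc2nc(Nc3ccc(N4CCN(C)CC4)cn3)ncc2Cl)cc1` at 8230 nM
compound 3 `CC(C)c1ccc(Nc2nc(Nc3ccc(N4CCN(C)CC4)cn3)ncc2Cl)cc1` at 1880 nM
Still unmeasured: compound 4 `CN1CCN(c2ccc(Nc3ncc(Cl)c(Nc4ccc(C(C)(C)C)cc4)n3)nc2)CC1`

Compound 3 stands lowest of the three at 1880 nM so far. Compound 4 takes isopropyl to tert-butyl, methyl in place of hydrogen on a saturated chain carbon bound to an aromatic carbon and two saturated chain carbons on a saturated chain carbon bound to an aromatic carbon and two saturated chain carbons. Among the measured compounds shown here, the closest precedent is a similar methyl addition, a modest step of a 4.4-fold lower number from compound 2 to compound 3 (0.64 log units; beyond the scatter) beyond the scatter. The modest 3.5-fold lower number from compound 1 to compound 2 (0.54 log units; beyond the scatter) and the large 15-fold lower number from compound 1 to compound 3 (1.18 log units; beyond the scatter) replace the whole group and bear less. With one precedent only, a smaller further fall in this assay is expected. The estimated step is a 2.4-fold lower number from compound 3 to compound 4 (0.37 log units; beyond the scatter) in that direction. For compound 4 the expected value is 800 nM with an estimated range of 250 nM to 2600 nM pending measurement.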

Compound 4, concentration for 50% growth inhibition: 12600 nM
Estimate against measurement, compound 4: 16-fold (1.20 log units) below; measured number outside the range, above it.
By their numbers in this assay, from the lowest: compound 3; then compounds 2 and 4 (each within the scatter of the next); then compound 1.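

In this assay the added methyl no longer lowers the number at this position: isopropyl to tert-butyl gives a 6.7-fold higher number from compound 3 to compound 4 (0.83 log units; beyond the scatter) and so reverses the fall seen from ethyl to isopropyl. Tert-butyl in place of ethyl gives a 1.5-fold higher number from compound 2 to compound 4 (0.18 log units; within the scatter), leaving compound 3 alone as the low point of these three alkyl groups. The tert-butyl compound keeps only a 2.3-fold lower number from compound 1 to compound 4 (0.35 log units; beyond the scatter) over the 4-(trifluoromethyl)benzyl compound.

From the compounds shown here alone, whether a cyclopropyl or methoxy group on the aromatic ring would match isopropyl remains open. No data given here bear on the reason for the reversal.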